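The source may hold more compounds than are shown below. What is called first, only, known or untested is meant among the compounds shown, and "the series" means these compounds.

Measured in a functional assay on MCF-10A cells (Homo sapiens) for antiproliferative activity, with a stated time of 48 h; on this read-out higher numbers stand for an effect only at larger amounts of compound and lower numbers for an effect already at smaller amounts:

- compound 1 `COc1ccc2nc(C)cc(NCc3ccc(C(C)(C)C)cc3)c2c1`: 6900 nM
- compound 2 `COc1ccc2nc(C)cc(NCc3c(F)cccc3C(F)(F)F)c2c1`: 14200 nM

Of these two compounds, compound 1 holds the lower number, at 6900 nM. Compound 2 stands higher at 14200 nM, a gap just beyond the usual scatter of this assay. The next compound to be tested is compound 3 `COc1ccc2nc(C)cc(NCc3ccc(-c4ccccc4)cc3)c2c1`. It carries phenyl in place of tert-butyl on an aromatic carbon, para to a large group (phenyl in place of tert-butyl on an aromatic carbon). Going by the values given here, no measured pair shows what this change does, so the data give no direct guide to its size or direction. The closest reference is compound 1 at 6900 nM, and no shift beyond the scatter is expected from it. The expected step is a 1.2-fold lower number from compound 1 to compound 3 (0.06 log units; within the scatter). For compound 3 the estimated value is 6000 nM, with an expected range from 2500 nM to 14000 nM.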

Compound 3, half-maximal effective concentration: 2800 nM
Beside the measured number, compound 3's estimate is 2.1-fold (0.33 log units) above it; measured number inside the range.
By their numbers in this assay, from the lowest: compound 3; then compound 1; then compound 2.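

In this assay, going by these compounds alone, the change from tert-butyl to phenyl on an aromatic carbon, para to a large group, gives a 2.5-fold lower number from compound 1 to compound 3 (0.39 log units; beyond the scatter), the first step at this position that can be read directly. The number therefore responds to the group held at this place, and a six-membered aromatic ring of carbon only is accepted there and goes with the lower value. Nothing available explains why this step has its direction or size.

A single step cannot show whether the ring itself or simply a different group at this position accounts for the shift. It also leaves open what a pyridine ring, a morpholine or a carboxylic acid would do at this position, and whether a methoxy group on the added phenyl would move the number further.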